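The source may hold more compounds than are shown below. What is called first, only, known or untested is meant among the compounds shown, and "the series" means these compounds.

Compound 3 `Cc1ccc(-c2cccc(COc3ccc(CCC(=O)O)cc3)c2)cc1` gives the highest number of the three measured in a functional assay on 1321-N1 cells for agonist activity at Free fatty acid receptor 1 (Homo sapiens), read by calcium flux; on this read-out higher numbers stand for an effect only at larger amounts of compound and lower numbers for an effect already at smaller amounts: compound 3 gives 490 nM, compound 2 `O=C(O)CCc1ccc(OCc2cccc(-c3ccccc3)c2)cc1` sits nearest with 135 nM, and compound 1 `O=C(O)CCc1ccc(OCc2cccc(Br)c2)cc1` furthest with 89.1 nM. The steps among them: a 1.5-fold higher number from compound 1 to compound 2 (0.18 log units; within the scatter); a 5.5-fold higher number from compound 1 to compound 3 (0.74 log units; beyond the scatter); a 3.6-fold higher number from compound 2 to compound 3 (0.56 log units; beyond the scatter). Thus exchanging bromo for an unsubstituted phenyl changed little, while the added methyl of compound 3 raised the number modestly.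

Compound 4 `COc1ccccc1-c1cccc(COc2ccc(CCC(=O)O)cc2)c1` continues from compound 3 by 2-methoxyphenyl in place of 4-methylphenyl on an aromatic carbon. Among the measured compounds shown here, the step bearing most directly on it is the one from compound 2 to compound 3, since the methyl that raised the number there is removed again; no measured step covers a methoxy group on this phenyl, so the direction of its own effect is unknown. The expectation is therefore a number returning part of the way toward compound 2, the step being a 2.0-fold lower number from compound 3 to compound 4 (0.29 log units; within the scatter). For compound 4 the estimate in this assay is 250 nM, within 90 nM to 700 nM.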

Compound 4, half-maximal effective concentration: 120 nM
Compound 4: the middle estimate sits 2.1-fold (0.32 log units) above what was measured; the range from low to high includes it.
By their numbers in this assay, from the lowest: compounds 1, 4 and 2 (each within the scatter of the next); then compound 3.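

In this assay, 2-methoxyphenyl in place of 4-methylphenyl gives a 4.1-fold lower number from compound 3 to compound 4 (0.61 log units; beyond the scatter), so the higher number of compound 3 does not extend to every substituted phenyl on this aromatic carbon. Methoxy in place of hydrogen leaves the number level, with a 1.1-fold lower number from compound 2 to compound 4 (0.05 log units; within the scatter), and 2-methoxyphenyl in place of bromo also stays within the scatter, with a 1.3-fold higher number from compound 1 to compound 4 (0.13 log units; within the scatter). Among the four compounds, only the 4-methylphenyl group of compound 3 stands apart, and no measurement shown accounts for this difference.

On these data alone, it remains open whether the higher number follows the methyl group itself or its location on the phenyl ring. A 2-methylphenyl and a 4-methoxyphenyl group at this position would separate these two readings.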